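Adding fluorine to compound 1: an expected step

This account rests on a few compounds, and the source may have more. Where it says the series, first, only, none or still open, it means among the compounds named here.

Measured so far:
compound 1 `CC(O)(CS(=O)(=O)c1ccc(F)cc1)c1nc(-c2ccc(Cl)cc2)no1`: > 100000 nM
compound 2 `CC(O)(CSc1ccc(Cl)cc1)c1nc(-c2ccc([N+](=O)[O-])c(C(F)(F)F)c2)no1`: 1300 nM
compound 3 `CC(O)(CS(=O)(=O)c1ccccc1)c1nc(-c2ccc(Cl)cc2)no1`: > 100000 nM

In a functional assay on DU-145 cells (Homo sapiens) for cytotoxicity, read by MTT assay (on this read-out higher numbers stand for weaker inhibition and lower numbers for stronger inhibition), compound 1 gives > 100000 nM, which is a limit of the assay rather than a number. Compound 3 gives > 100000 nM in this assay, again a limit. Compound 2 gives 1300 nM in this assay. Compound 1 therefore stands at the weak end of what is shown, sharing the limit of > 100000 nM in this assay, at which 2 of the 3 values shown sit, with compound 3. Compound 4 `CC(O)(CS(=O)(=O)c1ccc(F)cc1)c1nc(-c2ccc(F)c(Cl)c2)no1` differs from compound 1 by 3-chloro-4-fluorophenyl in place of 4-chlorophenyl on an aromatic carbon. For the measured compounds named here, the only one-place step among the measured compounds, a step that the two limits leave unreadable from compound 1 to compound 3, is unreadable, so no measured step sizes the change to compound 4. Given (the limit of > 100000 nM in this assay, at which 2 of the 3 values shown sit), compound 4 is expected to stay near that limit, and the step of a number no higher from compound 1 to compound 4 (the limit leaves the size open) is expected to be none beyond the scatter. Compound 4 is estimated at 100000 nM, between 20000 nM and 300000 nM.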

Compound 4, half-maximal inhibitory concentration: > 100000 nM
Compound 4 ended at the assay's limit (the forecaster's own chance of this, stated with the estimate: 75%); the middle value sits exactly at the limit.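

The step from compound 1 to compound 4 cannot be read, as both values are limits of the assay. The compounds shown leave open whether 3-chloro-4-fluorophenyl in place of 4-chlorophenyl changes cytotoxicity at all.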